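Hydroxyl ring to aminophenyl ring: what to expect

A few compounds are considered here, and "the series" means these few. Any claim that something is new, unique, unknown or untested is made for them only; others in the source may bear on it.

Three compounds sharing one core have been tested in an ADME assay on L929 cells (Mus musculus) for cytotoxicity, read by resazurin assay, with a stated time of 72 h; a higher number here means a weaker inhibitor, a lower number a stronger inhibitor:

compound 1, `COc1cc(C(=O)/C=C/c2ccc3c(c2)B(O)OC3)cc(OC)c1OC`, gives > 10 ug/mL, which is a limit of the assay rather than a number
compound 2, `O=C(/C=C/c1ccc2c(c1)B(O)OC2)c1ccccc1O`, gives > 10 ug/mL, again a limit of the assay
compound 3, `COCOc1ccccc1C(=O)/C=C/c1ccc2c(c1)B(O)OC2`, gives 9.02 ug/mL

Compound 2 thus stands at the limit of > 10 ug/mL in this assay, at which 2 of the 3 values shown sit, so only a limit, not a number, is known for it. Among the compounds with values here, the single measured step, an at least 1.1-fold lower number from compound 2 to compound 3 (0.04 log units; that floor lies within the scatter), stays within the scatter of the method and is the only guide available from the measured set.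

Compound 4, `Nc1cccc(C(=O)/C=C/c2ccc3c(c2)B(O)OC3)c1`, is not yet measured. It differs from compound 2 by 3-aminophenyl in place of 2-hydroxyphenyl on a carbonyl carbon. Within the data shown here, no measured step covers this particular change, so the expectation rests on the small size of an at least 1.1-fold lower number from compound 2 to compound 3 (0.04 log units; that floor lies within the scatter) and on compound 2 sitting at a limit. In this assay compound 4 is expected to give about 10 ug/mL, within a range from 6 ug/mL to 18 ug/mL. The expected step, a number no higher from compound 2 to compound 4 (the limit leaves the size open), is one not beyond the scatter, with a fair chance that the assay once more reports only a limit.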

Compound 4, half-maximal inhibitory concentration: 10 ug/mL
Beside the measured number, compound 4's estimate shows no gap at the digits printed; the measured number falls inside the stated range.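

In this assay, within the data shown here, compound 4, which carries 3-aminophenyl on the carbonyl carbon, gives 10 ug/mL, a measured number rather than a limit, and the first reading here for a ring bearing an amine at this place. Compound 2 gives > 10 ug/mL, which is a limit of the assay and not a number. The change from the 2-hydroxyphenyl ring to the 3-aminophenyl ring gives a number no higher from compound 2 to compound 4 (the limit leaves the size open), so this step cannot be read in size, and no gain or loss can be claimed for the change, because one end of the comparison is only a limit: the limit of > 10 ug/mL in this assay, at which 2 of the 4 values shown sit.

The two groups match in heavy atoms, hydrogen-bond donors and hydrogen-bond acceptors, yet they differ both in the group on the ring and in the number in the ring's name, and the compounds shown cannot tell which of these matters, if either does. From the compounds shown here alone, what a plain phenyl ring, or a phenyl ring carrying a carboxylic acid or a longer chain, would give on this carbonyl carbon remains open.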